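Swapping Diisopropylamino for Pyrrolidin-1-yl

The source may report more compounds than this note shows. Statements on the series, on what has been measured and on what is new or still open speak of the compounds shown alone.

Measured in a functional assay on HL-60 cells (Homo sapiens) for antiproliferative activity, read by MTT assay, with a stated time of 48 h; on this read-out higher numbers stand for weaker inhibition and lower numbers for stronger inhibition:
- Compound 1 `CC(C)=CCC[C@]1(C)/C=C/[C@@H](OC(=O)C=C(C)C)[C@](C)(O)/C=C/C(=O)/C(C(=O)O)=C\C1`: > 10000 nM (a limit, not a number)
- Compound 2 `CC(C)=CCC[C@]1(C)/C=C/[C@@H](OC(=O)C=C(C)C)[C@](C)(O)/C=C/C(=O)/C(CN(C(C)C)C(C)C)=C\C1`: 740 nM

Among the measured compounds shown here, compound 2 holds the only true number here, 740 nM. The value of compound 1, > 10000 nM, is a limit.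

Compound 3 `CC(C)=CCC[C@]1(C)/C=C/[C@@H](OC(=O)C=C(C)C)[C@](C)(O)/C=C/C(=O)/C(CN2CCCC2)=C\C1` differs from compound 2 in one place: pyrrolidin-1-yl in place of diisopropylamino on a saturated chain carbon bound to a double-bonded ring carbon. Pyrrolidin-1-yl stands in place of diisopropylamino on a saturated chain carbon bound to a double-bonded ring carbon.

For the measured compounds named here, only one measured step bears on this change, an at least 13-fold lower number from compound 1 to compound 2 (1.13 log units; beyond the scatter). It is large, but it replaces carboxy, which is absent from compound 3 as well. Going by the values given here, no measured step compares one amino group with another, so the size of this change cannot be read from the data. The best starting point is therefore compound 2 at 740 nM, with a wide range around it.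

No shift beyond the scatter is expected in this assay, and the expected step is a 1.1-fold higher number from compound 2 to compound 3 (0.03 log units; within the scatter). Compound 3 is estimated at 800 nM, with an expected range of 280 nM to 2500 nM.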

Compound 3, half-maximal inhibitory concentration: 160 nM
The estimate for compound 3 lay 5.0-fold (0.70 log units) above the measured number; measured number below the stated range.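

In this assay, among the compounds shown here, the earlier compounds showed only that an amino group on this saturated chain carbon differs sharply from carboxy on the double-bonded ring carbon; now the choice of amino group itself proves to matter, with a 4.6-fold lower number from compound 2 to compound 3 (0.67 log units; beyond the scatter). Replacing carboxy with (pyrrolidin-1-yl)methyl gives a still wider gap, with an at least 62-fold lower number from compound 1 to compound 3 (1.79 log units; beyond the scatter). Compound 1 carries a limit and not a number: the limit of > 10000 nM in this assay, at which 1 of the 3 values shown sits.

The single change from compound 2 to compound 3 both closes the open diisopropylamino group into a five-membered ring and lowers the heavy-atom count, so the compounds shown cannot separate these two differences, and nothing here explains the lower number. Diethylamino, an open-chain amine, and piperidin-1-yl, a six-membered cyclic amine, placed on the same saturated chain carbon would help show whether the ring, the ring size or the size of the whole group goes with the change.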